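From 2-Methoxyphenyl to 3,5-Dimethylphenyl in a Cytotoxic Series

This account rests on a few compounds, and the source may have more. Where it says the series, first, only, none or still open, it means among the compounds named here.

Of the compounds shown here, three sharing one core have been measured in a functional assay on A-431 cells (Homo sapiens) for cytotoxicity; on this read-out higher numbers stand for an effect only at larger amounts of compound and lower numbers for an effect already at smaller amounts. Compound 1 `COC1=C(C)C(=O)/C(=C(O)/C=C/c2cccc(OC)c2)C(=O)C1(C)C` gives 4.5 ug/mL, compound 2 `COC1=C(C)C(=O)/C(=C(O)/C=C/c2ccccc2OC)C(=O)C1(C)C` gives 6.6 ug/mL, and compound 3 `COC1=C(C)C(=O)/C(=C(O)/C=C/c2ccc(C)cc2)C(=O)C1(C)C` gives 5.1 ug/mL. On these numbers, compound 2 cannot be separated from the other two, as it lies within the scatter of both.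

Compound 4 `COC1=C(C)C(=O)/C(=C(O)/C=C/c2cc(C)cc(C)c2)C(=O)C1(C)C` keeps the shared core and alters only the aromatic group of compound 2: 3,5-dimethylphenyl in place of 2-methoxyphenyl on a double-bonded chain carbon bound to a double-bonded chain carbon. Three measured steps at this same place bear on the change. The closest is a 1.3-fold lower number from compound 2 to compound 3 (0.11 log units; within the scatter), where 4-methylphenyl replaces 2-methoxyphenyl. The other two are a 1.5-fold higher number from compound 1 to compound 2 (0.17 log units; within the scatter) and a 1.1-fold higher number from compound 1 to compound 3 (0.05 log units; within the scatter). Within the data shown here, all three stay within the scatter, although no measured compound carries the 3,5-dimethylphenyl group, so the evidence for it is indirect. No step beyond the scatter is therefore expected in this assay, and a value near that of compound 3, at 5.1 ug/mL, seems the most reasonable expectation. The estimate means a 1.3-fold lower number from compound 2 to compound 4 (0.10 log units; within the scatter), an expected step that would not be distinguishable from repeat variation. For compound 4, the estimated value is 5.2 ug/mL, with an expected range from 2.8 ug/mL to 9.5 ug/mL.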

Compound 4, concentration for half-maximal effect: 4 ug/mL
Compound 4: middle estimate off by 1.3-fold (0.11 log units), on the high side; the range from low to high includes it.
By their numbers in this assay, from the lowest: compounds 4, 1, 3 and 2 (each within the scatter of the next).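

In this assay, the 3,5-dimethylphenyl group on a double-bonded chain carbon bound to a double-bonded chain carbon cannot be separated from any of the three earlier aromatic groups, with a 1.7-fold lower number from compound 2 to compound 4 (0.22 log units; within the scatter) as the largest new step, alongside a 1.3-fold lower number from compound 3 to compound 4 (0.11 log units; within the scatter) and a 1.1-fold lower number from compound 1 to compound 4 (0.05 log units; within the scatter) as the smaller ones. Among these compounds, this is the first measured case at this place in which a group with two methyl substituents enters, and the exchange of 2-methoxyphenyl, with its hydrogen-bond acceptor, for an all-carbon group with none still leaves the number within the scatter, so all four aromatic groups now form a single flat set in this assay. No measured information is available to explain these small steps or to assign any of them to a property of the groups.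

Going by these compounds, it remains open whether any group at this place can produce a step beyond the scatter, for instance an aminophenyl group, a phenyl ring bearing a carboxylic acid, or a longer alkyl chain in place of the aromatic ring. Equally open, on these data alone, is whether the flat picture would hold for changes elsewhere on the shared core.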